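Removing a Methyl on a Fused Core: Expected Loss

The source may report more compounds than this note shows. Statements on the series, on what has been measured and on what is new or still open speak of the compounds shown alone.

Three compounds have been measured in a functional assay on CHO cells for antagonist activity at metabotropic glutamate receptor 5 (Rattus norvegicus), read by FLIPR and calcium flux; a higher number here means a weaker inhibitor, a lower number a stronger inhibitor:

Compound 1, `Cc1ccc2cnc(-c3cc(Cl)cc(Cl)c3)nc2n1`: 0.72 nM
Compound 2, `Cc1cc(F)cc(-c2ncc3ccc(C)nc3n2)c1`: 39.7 nM
Compound 3, `Clc1cc(Cl)cc(-c2ncc3cccnc3n2)c1`: 228 nM

Compound 1 and compound 2 share the same fused core but carry different aryl groups; the difference between the two cores is not broken down here. What compound 2 shows is a markedly higher number than compound 1 and a lower number than compound 3 in this assay.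

One change is seen directly. From compound 1 to compound 3 the methyl is removed: hydrogen in place of methyl on an aromatic carbon. The result is a 320-fold higher number from compound 1 to compound 3 (2.50 log units; beyond the scatter), a large loss of potency in this assay.

Compound 4, `Cc1cc(F)cc(-c2ncc3cccnc3n2)c1`, has not been measured. It is related to compound 2 by the same change: hydrogen in place of methyl on an aromatic carbon. The place lines for the two changes agree word for word, so this is the same change made on a different aryl partner.

The step from compound 2 to compound 4 is expected to be large in the same direction, because the step of a 320-fold higher number from compound 1 to compound 3 (2.50 log units; beyond the scatter) shows how much the methyl on this core contributes; the expected step is a 150-fold higher number from compound 2 to compound 4 (2.18 log units; beyond the scatter). Among the measured compounds shown here, with only one precedent, the size is uncertain, and a number this high may lie beyond what this assay can report. Compound 4 is estimated at 6000 nM, likely between 1500 nM and 25000 nM.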

Compound 4, half-maximal inhibitory concentration: 321 nM
Beside the measured number, compound 4's estimate is 19-fold (1.27 log units) above it, outside the stated range (below it).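

Removing the methyl weakens the compound on both aryl partners, but the loss is far from equal: in this assay the new step is an 8.1-fold higher number from compound 2 to compound 4 (0.91 log units; beyond the scatter). The direction of the change carries over from one aryl partner to the other, while its size does not, and the gap between the two steps is larger than repeated measurement would explain: the same change on two cores in this assay, a 320-fold higher number (2.50 log units; beyond the scatter) from compound 1 to compound 3 and an 8.1-fold higher number (0.91 log units; beyond the scatter) from compound 2 to compound 4, 39-fold (1.59 log units) apart, beyond the scatter of two such steps So in this series, the effect of this change on one compound does not give a reliable size for the same change on another, although the four compounds do not show why the two losses differ, nor whether the direction would hold with any further aryl partner.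

The compounds shown carry only a methyl or a hydrogen at this place on the shared core, so it remains open how an ethyl, a methoxy or an amine there would compare in this assay. Only two aryl partners appear as well, and a third, such as a phenyl ring bearing a nitrile, would be needed to show whether the size of the loss follows any pattern.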